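From Dichloro to Difluoro: an Expected Flat Step

This account rests on a few compounds, and the source may have more. Where it says the series, first, only, none or still open, it means among the compounds named here.

The measured compounds:
compound 1, `COc1cc(-c2cc(/C=C/C(=O)c3ccc(Cl)c(Cl)c3)[nH]n2)cc(OC)c1OC`: 94%
compound 2, `COc1ccc(-c2cc(/C=C/C(=O)c3ccc(N)cc3)[nH]n2)cc1OC`: 104%
compound 3, `COc1cc(C(=O)/C=C/c2cc(-c3cc(OC)c(OC)c(OC)c3)n[nH]2)cc(OC)c1OC`: 100%

In a functional assay on Malme-3M cells (Homo sapiens) for cytotoxicity, read by sulforhodamine B assay, with a stated time of 48 h, tested at 0.01 uM (a higher number here means a weaker effect of the compound at the concentration tested, a lower number a stronger effect), compound 1 gives 94%. This is the lowest of the three numbers, but compound 3 with 100% and compound 2 with 104% both sit within the usual scatter of it, so the three compounds cannot be told apart on these readings; all of them show little effect at the concentration tested.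

Compound 4, `COc1cc(-c2cc(/C=C/C(=O)c3ccc(F)c(F)c3)[nH]n2)cc(OC)c1OC`, has not yet been measured in this assay. It differs from compound 1 in one place: 3,4-difluorophenyl in place of 3,4-dichlorophenyl on a carbonyl carbon. For the measured compounds named here, no measured pair in this set isolates such a change, so nothing here shows how it acts on the read-out.

Because compound 1 itself gives 94%, near the top of the scale, the step of a number 3 percentage points higher from compound 1 to compound 4 (within the scatter) is expected to stay within the scatter, in no particular direction. Compound 4 is estimated at 97%, with a range from 85% to 110%.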

Compound 4, a percentage reported as activity, at one concentration (the size of the read-out at that concentration, not a potency): 93%
The estimate for compound 4 lay 4 percentage points above the measured number; low and high end bracket the measured number.
By their numbers in this assay, from the lowest: compounds 4, 1, 3 and 2 (each within the scatter of the next, the first and the last beyond it).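

In this assay, for the compounds shown here, 3,4-difluorophenyl in place of 3,4-dichlorophenyl on a carbonyl carbon gives a number 1 percentage points lower from compound 1 to compound 4 (within the scatter), the first step in this set that isolates a single change. At this one concentration, the read-out does not tell compound 1 and compound 4 apart, so this exchange of chlorine for fluorine on the phenyl shows no measurable effect here. Nothing at hand explains why the two compounds read alike.

As far as these compounds go, it remains open whether a group of a different kind on the same carbonyl carbon, such as a phenyl carrying a carboxylic acid or a morpholine, would move the read-out beyond the scatter. From the compounds shown here alone, it is also open whether compound 1 and compound 4 would separate at higher concentrations, where a larger effect could be read.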